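Phenyl for furan-3-yl on a shared core: a step past the limits

The compounds below may be only part of what the source reports. "The series", "measured", "known", "first", "only" and "open" are said of these compounds alone.

Measured so far:
Compound 1 `Nc1nc2c(c(-c3ccccc3)cn2[C@@H]2O[C@H](CO)[C@@H](O)[C@H]2O)c(=O)[nH]1` in a functional assay on A549 cells (Homo sapiens), read by MTT assay, with a stated time of 72 h (on this read-out higher numbers stand for weaker inhibition and lower numbers for stronger inhibition), gives > 100000 nM, which is a limit of the assay and not a number.
Compound 2 `O=c1[nH]cnc2c1c(-c1ccco1)cn2[C@@H]1O[C@H](CO)[C@@H](O)[C@H]1O` gives > 20000 nM, again a limit.
Compound 3 `O=c1[nH]cnc2c1c(-c1ccoc1)cn2[C@@H]1O[C@H](CO)[C@@H](O)[C@H]1O` gives > 20000 nM, also a limit.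

Compound 3 therefore stands nowhere definite on these numbers: its value is a limit, and the two other values are limits as well (the limit of > 100000 nM in this assay, at which 1 of the 3 values shown sits, (the limit of > 20000 nM in this assay, at which 2 of the 3 values shown sit)). Going by the values given here, the one step that can be read between measured compounds, a step that the two limits leave unreadable from compound 2 to compound 3, runs from one limit to another and so has no readable size.

Compound 4 `O=c1[nH]cnc2c1c(-c1ccccc1)cn2[C@@H]1O[C@H](CO)[C@@H](O)[C@H]1O` differs from compound 3 in one place: phenyl in place of furan-3-yl on an aromatic carbon. Among the compounds with values here, no measured step bears directly on this change. Compound 1 carries a phenyl at the same place, but it also differs from compound 4 at a second position on the shared core. Its value is only a limit.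

With every measured value a limit, no step beyond the scatter can be foreseen, and the expected step that the limit leaves unreadable from compound 3 to compound 4 is most likely unreadable. Compound 4 is expected to give about 60000 nM in this assay, within a range of 10000 nM to 300000 nM, and most probably to be reported again only as a limit.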

Compound 4, half-maximal inhibitory concentration: > 100000 nM
Compound 4: a limit, no number; the forecaster's own chance of this, stated with the estimate: 85%; middle value at least 1.6-fold (0.22 log units) from the limit.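

No new step can be read in this assay: the steps to compound 4 from compound 1, compound 2 and compound 3 each join one limit to another, so none has a size. The compounds shown leave open how strongly any of them inhibits, and whether changing phenyl, furan-2-yl, furan-3-yl or amino alters that at all.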